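The compounds below may be only part of what the source reports. "The series", "measured", "known", "first", "only" and "open" are said of these compounds alone.

Compound 3 `O=C(N1C[C@H](O)C=C[C@H]1COCc1ccccc1)n1cc(-c2ccc(-c3ccccc3)cc2)nn1` stands at the bottom of the series: in an assay on HEK293 cells for inhibition of diacylglycerol lipase-alpha (Homo sapiens), read by colorimetric assay, with stated times of 30 min, 60 s and 20 min (a higher number here means a weaker inhibitor, a lower number a stronger inhibitor), compound 3 gives only a limit, > 10000 nM, and no number. The two measured compounds beside it set the scale. Compound 1 `O=C(N1CCC=C[C@@H]1COCc1ccccc1)n1cc(-c2ccc(-c3ccccc3)cc2)nn1` gives 25.1 nM in this assay, and compound 2 `O=C(N1C[C@H](O)C=C[C@@H]1COCc1ccccc1)n1cc(-c2ccc(-c3ccccc3)cc2)nn1`, which carries a hydroxy in place of hydrogen on a saturated ring carbon, gives 25.1 nM; that step, no change at the digits printed from compound 1 to compound 2 (within the scatter), left the number where it was. The next step, an at least 390-fold higher number from compound 2 to compound 3 (2.60 log units; beyond the scatter), is the large one, with both the limit of > 10000 nM in this assay, at which 1 of the 3 values shown sits, and the fact that compounds 2 and 3 differ only in the configuration as drawn behind it.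

Compound 4 `O=C(N1C[C@@H](O)C=C[C@@H]1COCc1ccccc1)n1cc(-c2ccc(-c3ccccc3)cc2)nn1` is the mirror image of compound 3: the two compounds have the same atoms and bonds and differ only in configuration as drawn: 2 of 2 stereo elements differ (all stereocentres are inverted: mirror images); a stereocentre at a saturated ring carbon is drawn R in compound 3 and S in compound 4; a stereocentre at a saturated ring carbon is drawn S in compound 3 and R in compound 4. Both stereocentres are inverted, so the configuration that was drawn R in compound 2 and S in compound 3 returns to R in compound 4, while the hydroxy-bearing centre takes the configuration compound 2 did not have. The step bearing most on this change is an at least 390-fold higher number from compound 2 to compound 3 (2.60 log units; beyond the scatter), which is undone at one centre; the other centre is where the hydroxy entered, and no change at the digits printed from compound 1 to compound 2 (within the scatter) gave no signal for its surroundings. The step of an at least 160-fold lower number from compound 3 to compound 4 (2.22 log units; beyond the scatter) is therefore expected to be large and downward in this assay, bringing compound 4 off the limit. For compound 4 the estimate in this assay is 60 nM, within 15 nM to 400 nM.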

Compound 4, half-maximal inhibitory concentration: 31.6 nM
Estimate against measurement, compound 4: 1.9-fold (0.28 log units) above; low and high end bracket the measured number.
By their numbers in this assay, from the lowest: compounds 1, 2 and 4 (each within the scatter of the next). At a limit, above all of these: compound 3.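

In this assay the configuration at the hydroxy-bearing carbon gives no signal: a 1.3-fold higher number from compound 2 to compound 4 (0.10 log units; within the scatter) changes that centre alone, and a 1.3-fold higher number from compound 1 to compound 4 (0.10 log units; within the scatter) shows that the hydroxy in this second configuration also leaves the number within the scatter of the compound without it. The value of compound 3, > 10000 nM, is a limit of the assay and not a number. With the hydroxy-bearing centre silent in both configurations, an at least 310-fold lower number from compound 3 to compound 4 (2.50 log units; beyond the scatter) inverts both stereocentres, and the large step falls on the other stereocentre, where compound 3 alone among these four is drawn with the opposite configuration: the fact that compounds 3 and 4 differ only in the configuration as drawn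

Going by these compounds, how far compound 3 lies past its limit stays open, and so does the true size of the step at that stereocentre. Also open, on these data alone, are whether the hydroxy-bearing carbon would accept a methoxy, an amine or a carboxylic acid as readily as it accepts hydroxy in either configuration, and whether the mirror image of compound 2 would sit at the same limit as compound 3.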